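Shortening the Azo Aryl Group: Expectation for Compound 4

A few compounds are considered here, and "the series" means these few. Any claim that something is new, unique, unknown or untested is made for them only; others in the source may bear on it.

Measured so far:
Compound 1 `O=C(O)C1CCCN(CCCC=Cc2cccc(N=Nc3cccc4ccccc34)c2)C1` gives 11 h in a physicochemical assay for pharmacokinetics, read by spectrophotometry, in phosphate buffer, at pH 7.4, tested at 20 uM; a higher number here means that the compound lasts longer, a lower number that the compound disappears faster.
Compound 2 `O=C(O)C1CCCN(CCC#Cc2cccc(N=Nc3cccc4ccccc34)c2)C1` gives 18 h in this assay.
Compound 3 `O=C(O)C1CCCN(CCCC#Cc2cccc(N=Nc3cccc4ccccc34)c2)C1` gives 43.2 h in this assay.

Compound 1 stands lowest of the three numbers in this assay. Its nearest neighbour is compound 2, whose number lies within the usual scatter of that of compound 1, so no order between these two can be claimed. Compound 3 stands furthest away, beyond the scatter. Among the compounds with values here, the only step between compounds that differ in one place is a 2.4-fold higher number from compound 2 to compound 3 (0.38 log units; beyond the scatter), a change on the chain that links the carboxypiperidine to the aromatic part.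

Compound 4 `O=C(O)C1CCCN(CCCC=Cc2cccc(N=Nc3ccccc3)c2)C1` is not yet measured. It differs from compound 1 by phenyl in place of naphthalen-1-yl on a double-bonded nitrogen. Within the data shown here, no measured pair in this set alters that part of the molecule, so nothing here shows how such a change moves the half-life. The step from compound 2 to compound 3 concerns a different place and does not bear on it.

Among the measured compounds shown here, with no relevant measured step, the expected outcome for compound 4 is no change beyond the scatter, so compound 4 is estimated at 11 h, within 5 h to 25 h. That estimate means an expected step of no change at the digits printed from compound 1 to compound 4 (within the scatter).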

Compound 4, half-life: 288 h
Compound 4: the middle estimate sits 26-fold (1.42 log units) below what was measured; the whole stated range lies below it.
By their numbers in this assay, from the lowest: compounds 1 and 2 (each within the scatter of the next); then compound 3; then compound 4.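

In this assay, within the data shown here, the group on the double-bonded nitrogen proves to be a strong handle on half-life, a place no earlier pair had touched. Among these compounds, putting phenyl in place of naphthalen-1-yl gives a 26-fold higher number from compound 1 to compound 4 (1.42 log units; beyond the scatter) and is a large step, while the only earlier step, a 2.4-fold higher number from compound 2 to compound 3 (0.38 log units; beyond the scatter) on the chain, was modest. Nothing available explains why swapping two aromatic rings for one has so large an effect.

On these data alone, it remains open whether phenyl would raise the half-life to a similar extent on the triple-bonded chains of compound 2 and compound 3. As far as these compounds go, it is also open how a methoxy group or a chlorine atom on the phenyl, or a naphthalen-2-yl group in its place, would alter the half-life.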